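A few compounds are considered here, and "the series" means these few. Any claim that something is new, unique, unknown or untested is made for them only; others in the source may bear on it.

Compounds measured so far:
- compound 1 `CNC(=O)c1cc(Oc2ccc(NC(=O)c3nccc(-c4ccccc4)n3)cc2)ccn1`: 26200 nM
- compound 2 `CNC(=O)c1cc(Oc2ccc(NC(=O)c3cc(-c4ccc(C)cc4)ncn3)cc2)ccn1`: > 100000 nM (a limit of the assay, not a number)
- compound 3 `CCc1ccc(-c2cc(C(=O)Nc3ccc(Oc4ccnc(C(=O)NC)c4)cc3)ncn2)cc1`: 13300 nM

In a functional assay on A549 cells (Homo sapiens) for cytotoxicity, read by MTT assay, with a stated time of 72 h (a higher number here means a weaker inhibitor, a lower number a stronger inhibitor), compound 1 gives 26200 nM, and compound 3 gives 13300 nM. These two values lie within the usual scatter of each other. Compound 2 reads > 100000 nM, which is only a limit.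

The next compound, compound 4 `CNC(=O)c1cc(Oc2ccc(NC(=O)c3nccc(-c4cccc(Cl)c4)n3)cc2)ccn1`, keeps the core of compound 1 and has chloro in place of hydrogen on an aromatic carbon, turning phenyl into 3-chlorophenyl (chloro in place of hydrogen on an aromatic carbon). Within the data shown here, only one measured step offers any guide, an at least 7.5-fold lower number from compound 2 to compound 3 (0.87 log units; beyond the scatter). That step puts methyl in place of hydrogen on a saturated chain carbon bound to an aromatic carbon, so it involves a different group on a core that differs from that of compound 1. It also starts from a limit. Among the measured compounds shown here, no measured step shows what chloro does here, so it gives only a weak hint towards a lower number in this assay, and no step beyond the scatter is expected. The expected change is a 1.5-fold lower number from compound 1 to compound 4 (0.16 log units; within the scatter). For compound 4 the estimated value is 18000 nM, with an expected range from 6000 nM to 60000 nM.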

Compound 4, half-maximal inhibitory concentration: > 100000 nM
Compound 4: no number, only a limit (the forecaster's own chance of this, stated with the estimate: 10%); at least 5.5-fold (0.74 log units) between middle value and limit.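

Chloro in place of hydrogen, meta to a large group on the six-membered aromatic ring of carbon only, gives an at least 3.8-fold higher number from compound 1 to compound 4 (0.58 log units; beyond the scatter) in this assay. Among these compounds, this is the first measured change on the core of compound 1, and it runs the opposite way to the only earlier step, an at least 7.5-fold lower number from compound 2 to compound 3 (0.87 log units; beyond the scatter), which put methyl in place of hydrogen on a different core, so that step does not carry over to this change. As far as these compounds go, the real size of the new step stays unknown, because compound 4 reads only a limit: the limit of > 100000 nM in this assay, at which 2 of the 4 values shown sit.

The compounds shown leave open whether this rise belongs to chloro itself or to this place on the ring, a question that fluoro or methoxy at the same place, or chloro on a different carbon of that ring, could help to settle. They also leave open whether an amine or a carboxylic acid at this place would give a number close to that of compound 1, which stands at 26200 nM. From the compounds shown here alone, whether either group would instead reach the limit of the assay is equally open.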